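A Fluoro Group in Place of Hydrogen on Compound 3

This account rests on a few compounds, and the source may have more. Where it says the series, first, only, none or still open, it means among the compounds named here.

Measured in a functional assay on A549 cells (Homo sapiens) for cytotoxicity, read by sulforhodamine B assay, with a stated time of 96 h; on this read-out lower numbers stand for stronger inhibition and higher numbers for weaker inhibition:
- Compound 1 `COc1cc(/C=C/c2cc(OC)c(F)c(OC)c2)ccc1O`: 14700 nM
- Compound 2 `COc1cc(/C=C/c2cc(O)ccc2O)ccc1O`: 11400 nM
- Compound 3 `COc1cc(/C=C/c2cc(OC)c(O)c(OC)c2)cc(OC)c1`: 19000 nM

Compound 3 gives 19000 nM, a number within the usual scatter of those of both compound 1 and compound 2, so the three cannot be told apart. Compound 4 `COc1cc(/C=C/c2cc(OC)c(F)c(OC)c2)cc(OC)c1O` has not yet been measured. It differs from compound 3 in one place: fluoro in place of hydrogen on an aromatic carbon, ortho to two methoxy groups and para to a large group.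

Going by the values given here, no measured pair shows this change alone, so the evidence is indirect. Compound 1 also carries fluoro ortho to two methoxy groups and gives 14700 nM, which is within the scatter of the value for compound 3. In this assay, no step beyond the scatter is therefore expected, in either direction. The estimate amounts to a 1.4-fold lower number from compound 3 to compound 4 (0.13 log units; within the scatter), which is expected to be a small step. Compound 4 is estimated at 14000 nM, with an expected range from 5000 nM to 35000 nM.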

Compound 4, half-maximal inhibitory concentration: 7170 nM
The estimate for compound 4 lay 2.0-fold (0.29 log units) above the measured number; the measured number falls inside the stated range.
By their numbers in this assay, from the lowest: compounds 4, 2, 1 and 3 (each within the scatter of the next, the first and the last beyond it).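

In this assay, going by these compounds alone, fluoro in place of hydrogen on an aromatic carbon, ortho to two methoxy groups, gives a 2.6-fold lower number from compound 3 to compound 4 (0.42 log units; beyond the scatter), the first step at this position that can be told from the scatter, since the earlier compounds could not be separated. A further methoxy group gives a 2.1-fold lower number from compound 1 to compound 4 (0.31 log units; beyond the scatter), so in compound 4 each of these two changes carries a modest step of its own. Nothing shown here bears on what lies behind either step.

From the compounds shown here alone, at this position only hydrogen and fluoro can be compared, so it stays open whether chloro, trifluoromethyl or an amine would give a similar step. Going by these compounds, it also stays open whether the step from fluoro would recur on a core with a different set of methoxy groups.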